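A few compounds are considered here, and "the series" means these few. Any claim that something is new, unique, unknown or untested is made for them only; others in the source may bear on it.

Compound 1 `COc1ccc(-n2c(=O)n(Cc3cc4cc(Cl)ccc4n3CCCC#N)c3cnccc32)cc1OC` sits in an ADME assay on HeLa cells (Homo sapiens) for cytotoxicity, read by ATP content, with a stated time of 3 days (on this read-out lower numbers stand for higher toxicity in this test and higher numbers for lower toxicity in this test), at a limit rather than a number: compound 1 gives > 50000 nM (the limit of > 50000 nM in this assay, at which 1 of the 2 values shown sits). Compound 2 `CC(C)CCn1c(Cn2c(=O)n(C3CC3)c3ccncc32)nc2cnccc21` likewise stops at a limit, and in this assay compound 2 gives > 100000 nM (the limit of > 100000 nM in this assay, at which 1 of the 2 values shown sits). With both values shown being limits, compound 1 cannot be placed above or below compound 2. Compound 3 `N#CCCCn1c(Cn2c(=O)n(-c3ncccn3)c3ccncc32)cc2cc(Cl)ccc21` follows from compound 1 by pyrimidin-2-yl in place of 3,4-dimethoxyphenyl on an aromatic nitrogen. For the measured compounds named here, no measured step covers this change, and the expected step of a number no higher from compound 1 to compound 3 (the limit leaves the size open) is none beyond the scatter, most likely again reported as a limit. For compound 3 the estimate is 50000 nM, in the range 15000 nM to 200000 nM.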

Compound 3, half-maximal cytotoxic concentration: > 50000 nM
Compound 3: no number, only a limit; the forecaster's own chance of this, stated with the estimate: 75%; the middle value lies on the limit itself.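

Compound 3, like compound 1, ends at a limit in this assay, and no step can be read between them. The compounds shown leave open whether pyrimidin-2-yl in place of 3,4-dimethoxyphenyl changes the half-maximal cytotoxic concentration at all.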